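Chain extension on a pyrimidine-linked isothiocyanate in A549 cells

The source may report more compounds than this note shows. Statements on the series, on what has been measured and on what is new or still open speak of the compounds shown alone.

Measured compounds:
compound 1, `CN(C)C(=O)c1cc2cnc(Nc3ccc(S(=O)(=O)NCCCCN=C=S)cc3)nc2n1C1CCCC1` — in a functional assay on A549 cells (Homo sapiens) for inhibition, read by CCK-8 assay, with a stated time of 72 h, tested at 10 uM (a higher number here means a stronger effect of the compound at the concentration tested, a lower number a weaker effect), compound 1 gives 101%
compound 2, `CN(C)C(=O)c1cc2cnc(Nc3ccc(C(=O)NCCCCN=C=S)cc3)nc2n1C1CCCC1` — in this assay compound 2 gives 102%
compound 3, `CN(C)C(=O)c1cc2cnc(Nc3ccc(NC(=O)CCCN=C=S)cc3)nc2n1C1CCCC1` — in this assay compound 3 gives 102%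

Compound 3 sits level with compound 2, no change at the digits printed from compound 2 to compound 3 (within the scatter), and its gap to compound 1 is small, a number 1 percentage points higher from compound 1 to compound 3 (within the scatter). All three numbers lie within the scatter of one another, so no order among them can be read.

Compound 4, `CN(C)C(=O)c1cc2cnc(Nc3ccc(NC(=O)CCCCCN=C=S)cc3)nc2n1C1CCCC1`, has not yet been measured. It differs from compound 3 by a group of 5 heavy atoms (3 carbon, 1 nitrogen, 1 sulfur; no ring) in place of a group of 3 heavy atoms (1 carbon, 1 nitrogen, 1 sulfur; no ring), on a saturated chain carbon, three bonds along the chain from a carbonyl carbon.

The measured steps all concern the group attached to the aromatic carbon: a number 1 percentage points higher from compound 1 to compound 2 (within the scatter), a number 1 percentage points higher from compound 1 to compound 3 (within the scatter) and no change at the digits printed from compound 2 to compound 3 (within the scatter). Among the compounds with values here, none of them alters the saturated chain beyond the carbonyl, so no measured step matches the change from compound 3 to compound 4 directly. What they do show is that three different groups on that aromatic carbon give the same read-out within the scatter, and since the read-out of compound 3 is already near complete inhibition, no step beyond the scatter is expected in this assay.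

Compound 4 is therefore estimated at 100%, with a range from 85% to 105%. The expected step is a number 2 percentage points lower from compound 3 to compound 4 (within the scatter).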

Compound 4, a percentage reported as inhibition, at one concentration (the size of the read-out at that concentration, not a potency): 100%
Estimate against measurement, compound 4: no gap at the digits printed, and the stated range covers the measured number.
By their numbers in this assay, from the lowest: compounds 4, 1, 2 and 3 (each within the scatter of the next).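

In this assay, within the data shown here, compound 4 is the only compound here that alters the saturated chain, three bonds along from a carbonyl carbon, and putting the group of 5 heavy atoms in place of the group of 3 heavy atoms gives a number 2 percentage points lower from compound 3 to compound 4 (within the scatter). Among these compounds, the comparisons that also change the group on the aromatic carbon read the same way, with a number 2 percentage points lower from compound 2 to compound 4 (within the scatter) and a number 1 percentage points lower from compound 1 to compound 4 (within the scatter), so this change to the chain, like the earlier changes, produces no step that can be told from the scatter at a read-out already near complete inhibition. Nothing measured alongside these numbers offers an explanation for this result.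

Going by these compounds, whether a longer chain, or an amine or a carboxylic acid in place of the isothiocyanate, would lower the read-out remains open. With only one concentration and no potency, any real differences among compound 1, compound 2, compound 3 and compound 4 also remain unresolved.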